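Lengthening the Amide Chain on Compound 2

This account rests on a few compounds, and the source may have more. Where it says the series, first, only, none or still open, it means among the compounds named here.

Of the compounds shown here, three have been tested in a functional assay on NCI-H1975 cells (Homo sapiens) for antiproliferative activity, read by CCK-8 assay, with a stated time of 72 h; a higher number here means a weaker inhibitor of growth, a lower number a stronger inhibitor of growth. Compound 1 `CCC1C(=O)N(C)c2cnc(Nc3ccc(S(=O)(=O)NCCO)cc3)nc2N1c1ccn(C)n1` gives "not active" (no number reported), with no number reported. Compound 2 `CCC1C(=O)N(C)c2cnc(-n3ccc4cc(C(=O)NC)ccc43)nc2N1c1ccn(C)n1` gives 35700 nM, and compound 3 `CCCNC(=O)c1ccc2c(ccn2-c2ncc3c(n2)N(C2CCCC2)[C@H](CC)C(=O)N3C)c1` gives 786 nM. Compound 2 therefore holds the higher of the two numbers, and the gap lies beyond the usual scatter. However, these two compounds differ in more than one place, so the gap cannot be assigned to any single change.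

Compound 4 `CCCCNC(=O)c1ccc2c(ccn2-c2ncc3c(n2)N(c2ccn(C)n2)C(CC)C(=O)N3C)c1` has not yet been measured. It turns the methylcarbamoyl of compound 2 into butylcarbamoyl: propyl in place of hydrogen on a saturated chain carbon bound to an amide-type nitrogen. Going by the values given here, no measured pair isolates this change, so any forecast is loose. Compound 3, with a propyl chain on its amide, reaches 786 nM, which hints at a lower number in this assay, though probably not one that low. The expected change is a moderate step downward, estimated as a 3.0-fold lower number from compound 2 to compound 4 (0.47 log units; beyond the scatter). For compound 4 the estimated value is 12000 nM, with an expected range of 3000 nM to 40000 nM.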

Compound 4, concentration for 50% growth inhibition: 12000 nM
The estimate for compound 4 equals the measured number at the digits printed; the measured number falls inside the stated range.
By their numbers in this assay, from the lowest: compound 3; then compound 4; then compound 2.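

In this assay, going by these compounds alone, the amide chain gives the first change that can be read on its own: going from methylcarbamoyl to butylcarbamoyl produces a 3.0-fold lower number from compound 2 to compound 4 (0.47 log units; beyond the scatter) with nothing else altered. The step is modest, but it shows that this position accepts a longer chain without loss of growth inhibition, and that a longer chain here can lower the number. Even so, compound 4 remains at 12000 nM in this assay and nothing measured here explains the drop.

From the compounds shown here alone, it remains open whether a chain longer than butyl, a branched chain such as isopropyl, or a chain ending in an amine or a carboxylic acid would lower the number further. Also open, going by these compounds, is how much of the gap to compound 3 belongs to the amide chain, since compound 3 differs from both compound 2 and compound 4 in more than one place.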